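Swapping a Ring Carbonyl for a Hydroxyl: Expected Cytotoxicity

The compounds below may be only part of what the source reports. "The series", "measured", "known", "first", "only" and "open" are said of these compounds alone.

Measured so far:
compound 1 `CC(O)C1CCCCN(S(=O)(=O)c2cc(C(=O)Nc3ccc(F)c(Cl)c3)ccc2F)C1`: 2600 nM
compound 2 `CN1CCCN(S(=O)(=O)c2cc(C(=O)Nc3ccc(F)c(Cl)c3)ccc2F)CC1=O`: > 100000 nM

In an ADME assay on HepG2 2.2.15 cells (Homo sapiens) for cytotoxicity, read by luminescence, with a stated time of 3 days (on this read-out lower numbers stand for higher toxicity in this test and higher numbers for lower toxicity in this test), compound 1 gives 2600 nM. For compound 2 this assay reports only a limit, > 100000 nM, which is the limit of > 100000 nM in this assay, at which 1 of the 2 values shown sits; no number was reached. The step of an at least 38-fold higher number from compound 1 to compound 2 (1.58 log units; beyond the scatter) carried the result up to that limit. Compound 3 `CN1CCN(S(=O)(=O)c2cc(C(=O)Nc3ccc(F)c(Cl)c3)ccc2F)CC(O)C1` keeps the core of compound 2 and changes only the ring on the sulfonyl sulfur: 6-hydroxy-4-methyl-1,4-diazepan-1-yl in place of 4-methyl-3-oxo-1,4-diazepan-1-yl on a sulfonyl sulfur. For the measured compounds named here, no measured step covers this change; the single measured step concerns a different ring, so it offers no direct guide. Compound 3 is therefore expected to remain near the limit, with an estimated step of an at least 1.6-fold lower number from compound 2 to compound 3 (0.22 log units; that floor lies within the scatter). For compound 3 the estimate is 60000 nM, between 15000 nM and 100000 nM.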

Compound 3, half-maximal cytotoxic concentration: 31000 nM
Compound 3: the middle estimate sits 1.9-fold (0.29 log units) above what was measured; low and high end bracket the measured number.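

In this assay, the ring on the sulfonyl sulfur moves the read-out even when its heavy-atom count stays the same: there is an at least 3.2-fold lower number from compound 2 to compound 3 (0.50 log units; beyond the scatter) when a ring hydroxyl replaces the carbonyl. Compound 2 holds no number, only a limit: the limit of > 100000 nM in this assay, at which 1 of the 3 values shown sits. Even so, the hydroxyl-bearing diazepane stays well on the less toxic side of the azepane, with a 12-fold higher number from compound 1 to compound 3 (1.08 log units; beyond the scatter).

On these data alone, the full size of the carbonyl-to-hydroxyl step remains open. So does how a methoxy or an amine at the hydroxyl's place would read.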